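This account rests on a few compounds, and the source may have more. Where it says the series, first, only, none or still open, it means among the compounds named here.

Compound 1 `CCN1CCN(C[C@H]2CN(c3ccc(-n4cc(-c5ccccn5)cn4)c(F)c3)C(=O)O2)CC1` gives 706000 nM in a physicochemical assay for solubility, read by HPLC, with a stated time of 24 h; a lower number here means a less soluble compound, a higher number a more soluble compound. Compound 2 `COC(=O)CC1CCN(C[C@H]2CN(c3ccc(-n4cc(-c5ccccn5)cn4)c(F)c3)C(=O)O2)CC1` gives 92100 nM in this assay. Compound 3 `O=C1O[C@@H](CN2CCC(O)CC2)CN1c1ccc(-n2cc(-c3ccccn3)cn2)c(F)c1` gives 45900 nM in this assay.

Compound 3 stands at the low end of these three: its gap to compound 2, a 2.0-fold lower number from compound 2 to compound 3 (0.30 log units; within the scatter), is within the scatter, while a 15-fold lower number from compound 1 to compound 3 (1.19 log units; beyond the scatter) is large. Compound 4 `O=C1O[C@@H](Cn2ccnn2)CN1c1ccc(-n2cc(-c3ccccn3)cn2)c(F)c1` differs from compound 3 by 1H-1,2,3-triazol-1-yl in place of 4-hydroxypiperidin-1-yl on a saturated chain carbon bound to a saturated ring carbon. Among the measured compounds shown here, no measured step exchanges a saturated ring for an aromatic one, so the measured steps bear on it only loosely: the two departures from 4-ethylpiperazin-1-yl, a 7.7-fold lower number from compound 1 to compound 2 (0.88 log units; beyond the scatter) and a 15-fold lower number from compound 1 to compound 3 (1.19 log units; beyond the scatter), both lowered the number, whereas a 2.0-fold lower number from compound 2 to compound 3 (0.30 log units; within the scatter) stayed within the scatter. Compound 4 is therefore expected to move modestly lower, a 2.3-fold lower number from compound 3 to compound 4 (0.36 log units; beyond the scatter). Compound 4 is estimated at 20000 nM, with a range from 5000 nM to 80000 nM.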

Compound 4, solubility: 247000 nM
Estimate against measurement, compound 4: 12-fold (1.09 log units) below; the whole stated range lies below it.
By their numbers in this assay, from the lowest: compounds 3 and 2 (each within the scatter of the next); then compound 4; then compound 1.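

On a saturated chain carbon bound to a saturated ring carbon, 1H-1,2,3-triazol-1-yl gives a higher number in this assay than either piperidine group (a 5.4-fold higher number from compound 3 to compound 4 (0.73 log units; beyond the scatter) and a 2.7-fold higher number from compound 2 to compound 4 (0.43 log units; beyond the scatter)), so departures from 4-ethylpiperazin-1-yl need not fall as far as those two did. The 4-ethylpiperazin-1-yl group still stays on top (a 2.9-fold lower number from compound 1 to compound 4 (0.46 log units; beyond the scatter)). Nothing shown explains these differences.

On these data alone, it remains open whether this rise is particular to the triazole or would also appear with an imidazole or a tetrazole at this position.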